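This account rests on a few compounds, and the source may have more. Where it says the series, first, only, none or still open, it means among the compounds named here.

Three measured members of this series cluster closely. Compound 1 `COc1ccc(/C=C/C(=O)CC(C)=O)cc1OC` gives 10600 nM in a functional assay on MCF7 cells (Homo sapiens) for cytotoxicity, read by MTT assay, with a stated time of 72 h; on this read-out higher numbers stand for weaker inhibition and lower numbers for stronger inhibition. For the measured compounds named here, compound 2 `COc1ccc(/C=C/c2cc(C)n[nH]2)cc1OC` gives 12600 nM in this assay, and the step of a 1.2-fold higher number from compound 1 to compound 2 (0.08 log units; within the scatter) is the only single-point change measured so far. Compound 3 `COc1cc(/C=C/c2cc(C)no2)ccc1O` gives 20900 nM in this assay; this is the highest number of the three, but its nearest neighbour is compound 2 and its furthest is compound 1, and both separations fall within the scatter, so the three values are not distinguished.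

Compound 4 `COc1ccc(/C=C/c2cc(C)no2)cc1OC` differs from compound 3 by methyl in place of hydrogen on an oxygen on an aromatic ring. Going by the values given here, no measured step changes a hydrogen on an aromatic oxygen for a methyl, so the one measured step, that from compound 1 to compound 2, concerns a different part of the molecule and does not bear on this change. What the numbers do show is that compounds 1, 2 and 3, which differ at several places, all sit within the scatter of one another in this assay.

The expected step of a 1.4-fold lower number from compound 3 to compound 4 (0.14 log units; within the scatter) is therefore not beyond the scatter, with no direction favoured. The estimate for compound 4 in this assay is 15000 nM, within a range of 6000 nM to 40000 nM.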

Compound 4, half-maximal inhibitory concentration: > 100000 nM
Compound 4 was reported as a limit; the forecaster's own chance of this, stated with the estimate: 10%; at least 6.6-fold (0.82 log units) between middle value and limit.
By their numbers in this assay, from the lowest: compounds 1, 2 and 3 (each within the scatter of the next). At a limit, above all of these: compound 4.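

Compound 4 is reported only as a limit in this assay, not as a number: the limit of > 100000 nM in this assay, at which 1 of the 4 values shown sits.

For the compounds shown here, at this oxygen on an aromatic ring, hydroxy to methoxy gives the first step beyond the scatter, an at least 4.7-fold higher number from compound 3 to compound 4 (0.67 log units; beyond the scatter), and its full size stays unknown. The same result separates compound 4 from the other two compounds that differ from it in one place, with 3-methyl-1,2-oxazol-5-yl replacing 3-methyl-1H-pyrazol-5-yl in an at least 7.9-fold higher number from compound 2 to compound 4 (0.89 log units; beyond the scatter) and (2-oxopropyl)carbonyl in an at least 9.4-fold higher number from compound 1 to compound 4 (0.97 log units; beyond the scatter). Compound 3 carries the same 3-methyl-1,2-oxazol-5-yl and gives 20900 nM, so that group alone does not mark out compound 4.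

The compounds shown leave open whether an ethyl group or a longer chain ending in an amine on this oxygen would behave as the methyl does, since only hydrogen and methyl are compared there. They also leave open whether hydroxy to methoxy has a similar effect when 3-methyl-1H-pyrazol-5-yl or (2-oxopropyl)carbonyl stands on the chain, and they give no reason for the step.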